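This account rests on a few compounds, and the source may have more. Where it says the series, first, only, none or still open, it means among the compounds named here.

Working notes on the shared core in a functional assay on K562 cells (Homo sapiens) for cytotoxicity, read by MTT assay, with a stated time of 72 h; on this read-out lower numbers stand for higher toxicity in this test and higher numbers for lower toxicity in this test. Compound 1 `CS/C(=N\C(=O)c1sccc1Cl)NC(=O)c1sccc1Cl` gives > 100000 nM, which is a limit of the test and not a number. Compound 2 `CS/C(=N\C(=O)c1ccno1)NC(=O)c1ccno1` gives > 100000 nM, again a limit rather than a number. Going by the values given here, compound 3 `CS/C(=N\C(=O)c1cc2ccccc2s1)NC(=O)c1cc2ccccc2s1` gives 98600 nM, the only number in the set. Among the compounds with values here, compound 2 thus stands at the limit of > 100000 nM in this assay, at which 2 of the 3 values shown sit, and no compound in the set is separated from another beyond the scatter. Compound 4 `O=C(/N=C(/NC(=O)c1ccno1)[Se]Cc1ccccc1)c1ccno1` is not yet measured; it differs from compound 2 by a group of 8 heavy atoms (7 carbon, 1 selenium; one six-membered aromatic ring of carbon only) in place of a group of 2 heavy atoms (1 carbon, 1 sulfur; no ring), on a carbon with a double bond to nitrogen. Within the data shown here, no measured step of this kind exists in the set. The step from compound 2 to compound 4 is therefore expected to be small, an at least 1.6-fold lower number from compound 2 to compound 4 (0.22 log units; that floor lies within the scatter), with a possible shift toward a number rather than a limit. Compound 4 is estimated at 60000 nM, with a range from 20000 nM to 150000 nM.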

Compound 4, concentration lethal to 50% of the cells: 94700 nM
Compound 4: middle estimate off by 1.6-fold (0.20 log units), on the low side; the range from low to high includes it.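

Going by these compounds alone, at the carbon with a double bond to nitrogen, replacing methylsulfanyl with the selenium-bearing group and its six-membered aromatic ring gives the first step at this place in this assay: an at least 1.0-fold lower number from compound 2 to compound 4 (0.02 log units; that floor lies within the scatter). Compound 4 reads as a number, 94700 nM. Compound 2 remains a limit of the test, so only a floor can be given for the step: the limit of > 100000 nM in this assay, at which 2 of the 4 values shown sit.

Selenium and the ring enter together, so their separate contributions remain open. Also open, going by these compounds, is how a benzylsulfanyl group or an amine at this carbon would read.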